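Fluoro on the styryl ring of the anilide series

A few compounds are considered here, and "the series" means these few. Any claim that something is new, unique, unknown or untested is made for them only; others in the source may bear on it.

The series rests on an enamide core; compound 1 is `CO/C(=C\c1ccccc1)C(=O)Nc1ccccc1` and compound 2 is `CO/C(=C\c1ccccc1)C(=O)Nc1ccc(C(C)C)cc1`. In a functional assay on cells (Splenocyte, Mus musculus, strain BALB/c) for inhibition, read by MTT assay, with a stated time of 48 h (a higher number here means a weaker inhibitor, a lower number a stronger inhibitor), compound 1 gives 15200 nM, while compound 2 gives 3460 nM. Among the compounds with values here, the one step recorded so far, a 4.4-fold lower number from compound 1 to compound 2 (0.64 log units; beyond the scatter), concerns the anilide side only. On the numbers shown, compound 2 stands lowest of the two, with compound 1 as its nearest neighbour.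

Compound 3 is `CO/C(=C\c1ccc(F)cc1)C(=O)Nc1ccc(C(C)C)cc1`. Relative to compound 2 the change is fluoro in place of hydrogen on an aromatic carbon; read one bond further out, it is phenyl to 4-fluorophenyl on the styryl side, the anilide being kept unchanged. Within the data shown here, no measured step touches this ring, so the recorded step from compound 1 to compound 2 gives no direct guide, and there is nothing in the data to set the sign of the change. A small substituent of this kind is expected to leave the number near that of compound 2, and the step of a 1.2-fold lower number from compound 2 to compound 3 (0.06 log units; within the scatter) is estimated to stay within the scatter. For compound 3 the estimate in this assay is 3000 nM, with a range of 1200 nM to 7500 nM.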

Compound 3, half-maximal inhibitory concentration: 4660 nM
Compound 3: middle estimate off by 1.6-fold (0.19 log units), on the low side; measured number inside the range.
By their numbers in this assay, from the lowest: compounds 2 and 3 (each within the scatter of the next); then compound 1.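

In this assay, within the data shown here, the only measured step on the styryl side, a 1.3-fold higher number from compound 2 to compound 3 (0.13 log units; within the scatter), lies within the scatter, so the numbers of these two compounds cannot be told apart and the sign of the step carries no meaning. Among these compounds, with the isopropyl anilide kept, this place on the aromatic ring, para to a large group, therefore accepts fluoro in place of hydrogen without a readable effect, and the only step beyond the scatter remains the one on the anilide side, a 4.4-fold lower number from compound 1 to compound 2 (0.64 log units; beyond the scatter). No measurement at hand offers an explanation for this result.

Fluoro is the only replacement shown on this ring, so it remains open whether chloro, methoxy or a carboxylic acid at the same place would also stay within the scatter of compound 2. Also open, from the compounds shown here alone, is whether the fluoro step reads the same on the unsubstituted anilide of compound 1, and whether an amine or a longer alkyl chain on the anilide side would take the number further than isopropyl does.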